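Removing a Methylpiperazine: Expected Cytotoxicity of Compound 3

A few compounds are considered here, and "the series" means these few. Any claim that something is new, unique, unknown or untested is made for them only; others in the source may bear on it.

Compound 1, `COc1cc(Nc2nc(C(=N)Nc3ccc(N4CCN(C)CC4)cc3)cc3c(-c4ccccc4)n[nH]c23)cc(OC)c1OC`: 3400 nM
Compound 2, `COc1ccc(Cn2cc3cc(C(=N)Nc4ccc(N5CCN(C)CC5)cc4)ncc3n2)cc1`: 3200 nM

Both numbers come from a functional assay on HT-1080 cells (Homo sapiens) for cytotoxicity, read by MTT assay, with a stated time of 72 h; a lower number here means a stronger inhibitor, a higher number a weaker inhibitor. Compound 1 carries the higher of the two numbers, though compound 2 lies so close that the gap is within the usual scatter, so neither can be called the stronger. Compound 3, `COc1cc(Nc2nc(C(=N)Nc3ccccc3)cc3c(-c4ccccc4)n[nH]c23)cc(OC)c1OC`, has not been measured. It differs from compound 1 by hydrogen in place of 4-methylpiperazin-1-yl on an aromatic carbon. Within the data shown here, no measured pair isolates this change, so its effect is unknown; a modest weakening is expected, a 2.1-fold higher number from compound 1 to compound 3 (0.31 log units; beyond the scatter). For compound 3 the estimate is 7000 nM, ranging from 2000 nM to 25000 nM.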

Compound 3, half-maximal inhibitory concentration: 3900 nM
The estimate for compound 3 lay 1.8-fold (0.25 log units) above the measured number; measured number inside the range.
By their numbers in this assay, from the lowest: compounds 2, 1 and 3 (each within the scatter of the next).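

In this assay, putting hydrogen in place of 4-methylpiperazin-1-yl on this aromatic carbon gives a 1.1-fold higher number from compound 1 to compound 3 (0.06 log units; within the scatter). A group of this size can therefore go from this position, para to a large group, with no difference this assay can resolve, and the cytotoxicity of compound 1 does not rest on the group. Nothing at hand explains this result. From the compounds shown here alone, whether a small amine such as dimethylamino or a carboxylic acid at this position would match hydrogen stays open, and so does whether the same replacement would hold on other cores.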